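Solubility notes: piperidine amide replacement for the benzoic acid

The compounds below may be only part of what the source reports. "The series", "measured", "known", "first", "only" and "open" are said of these compounds alone.

Measured compounds:
compound 1 `O=C(O)c1cccc(S(=O)(=O)N2CCC(NS(=O)(=O)c3cc(S(=O)(=O)c4ccccc4)ccc3C(F)(F)F)CC2)c1` — 12500 nM
compound 2 `O=S(=O)(NC1CCN(S(=O)(=O)c2cccc(-c3nnn[nH]3)c2)CC1)c1cc(S(=O)(=O)c2ccccc2)ccc1C(F)(F)F` — 100000 nM
compound 3 `CC(C)(C)OC(=O)N1CCC(CC(=O)N2CCC(NS(=O)(=O)c3cc(S(=O)(=O)c4ccccc4)ccc3C(F)(F)F)CC2)CC1` — 12500 nM

In a physicochemical assay for solubility (on this read-out higher numbers stand for higher solubility and lower numbers for lower solubility), compound 1 gives 12500 nM, level with compound 3 at the digits shown and together the lowest of the three numbers. Compound 2 gives the highest number, with an 8.0-fold higher number from compound 1 to compound 2 (0.90 log units; beyond the scatter).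

Compound 4 `O=C(C1CCNCC1)N1CCC(NS(=O)(=O)c2cc(S(=O)(=O)c3ccccc3)ccc2C(F)(F)F)CC1` carries (piperidin-4-yl)carbonyl in place of (3-carboxyphenyl)sulfonyl on an amine nitrogen in a ring. For the measured compounds named here, no measured step covers this change directly. Compound 3, which also replaces the (3-carboxyphenyl)sulfonyl with a carbonyl-linked piperidine, stands level with compound 1 in this assay, so that part of the change by itself gives no step beyond the scatter. Compound 4 differs from compound 3 in leaving the ring nitrogen of the piperidin-4-yl free, for which no comparison is available. A modest rise is expected, of the order of a 3.2-fold higher number from compound 1 to compound 4 (0.51 log units; beyond the scatter), with wide uncertainty. Compound 4 is therefore estimated at 40000 nM, within a range of 10000 nM to 160000 nM.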

Compound 4, solubility: 100000 nM
Compound 4: middle estimate off by 2.5-fold (0.40 log units), on the low side; measured number inside the range.
By their numbers in this assay, from the lowest: compounds 1 and 3 (each within the scatter of the next); then compounds 2 and 4 (each within the scatter of the next).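

In this assay, the (3-carboxyphenyl)sulfonyl on the amine nitrogen in a ring is not required for a number well above that of compound 1: (piperidin-4-yl)carbonyl in its place gives an 8.0-fold higher number from compound 1 to compound 4 (0.90 log units; beyond the scatter). That group has no aromatic ring and no carboxy, yet compound 2 stands level with compound 4 at 100000 nM, so the top value among these compounds is no longer confined to an aromatic sulfonyl carrying 1H-tetrazol-5-yl. No measurement shown explains the step.

The compounds shown do not separate the contribution of the carbonyl link from that of the piperidin-4-yl ring, which a (piperidin-4-yl)sulfonyl at the same nitrogen would address. They also leave open whether the free ring nitrogen matters, a question for a methyl or an acetyl on that nitrogen.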